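This account rests on a few compounds, and the source may have more. Where it says the series, first, only, none or still open, it means among the compounds named here.

The measured compounds:
compound 1, `c1ccc2oc(-c3cn4nc(C5CC5)sc4n3)cc2c1`, 530 nM;
compound 2, `CCOc1nn2cc(-c3cc4ccccc4o3)nc2s1`, 67 nM;
compound 3, `COc1cc(OCc2ccccc2OCc2ccccc2)c2cc(-c3cn4nc(OC)sc4n3)oc2c1`, 3.2 nM.

In a functional assay on HEK293 cells for antagonist activity at proteinase-activated receptor 4 (Homo sapiens), read by FLIPR and calcium flux, with a stated time of 30 min (a lower number here means a stronger inhibitor, a higher number a weaker inhibitor), compound 2 stands second highest of the three numbers. Its nearest neighbour is compound 1, which gives 530 nM; the step of a 7.9-fold lower number from compound 1 to compound 2 (0.90 log units; beyond the scatter) is modest but beyond the scatter. Within the data shown here, compound 3, with 3.2 nM, lies furthest from compound 2, and no single-point step joins those two, so their values are simply noted side by side.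

Compound 4, `CS(=O)(=O)c1nn2cc(-c3cc4ccccc4o3)nc2s1`, has not yet been measured in this assay. It differs from compound 2 in one place: methylsulfonyl in place of ethoxy on an aromatic carbon. Among the measured compounds shown here, the only measured step that touches this aromatic carbon is the one from compound 1 to compound 2, where ethoxy in place of cyclopropyl lowered the number. For the measured compounds named here, no measured step involves methylsulfonyl, so the direction of a change from ethoxy to this group is not anchored by the data. A step of uncertain sign and wide range is therefore expected in this assay, more likely toward a higher number. Compound 4 is estimated at 200 nM, with a range from 40 nM to 1500 nM. The expected step is a 3.0-fold higher number from compound 2 to compound 4 (0.47 log units; beyond the scatter).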

Compound 4, half-maximal inhibitory concentration: 820 nM
Estimate against measurement, compound 4: 4.1-fold (0.61 log units) below; the measured number falls inside the stated range.
By their numbers in this assay, from the lowest: compound 3; then compound 2; then compounds 1 and 4 (each within the scatter of the next).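

The aromatic carbon next to the ring nitrogen and the ring sulfur now carries a second replacement for ethoxy, and this one runs in the opposite direction to the earlier step: in this assay the change to methylsulfonyl gives a 12-fold higher number from compound 2 to compound 4 (1.09 log units; beyond the scatter). Methylsulfonyl and cyclopropyl, two very different groups, cannot be told apart at this place, with a 1.5-fold higher number from compound 1 to compound 4 (0.19 log units; within the scatter), so among the three groups compared on this core, ethoxy alone stands apart with the lower number. Nothing in the available data accounts for this difference between the groups.

On these data alone, it remains open whether ethoxy's advantage belongs to the oxygen attached to the ring or to the group as a whole, and a longer propoxy chain, a butoxy chain or an amine at this carbon would help to separate these possibilities. Also open, as far as these compounds go, is whether a step of this size would carry over to the more heavily substituted core of compound 3, since no single-change comparison links that compound to the others.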